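A few compounds are considered here, and "the series" means these few. Any claim that something is new, unique, unknown or untested is made for them only; others in the source may bear on it.

Measured compounds:
- compound 1, `CC(C)n1cc(-c2ccnc3[nH]c(C4CCNCC4)cc23)ccc1=O`, -0.2
- compound 2, `COc1cc(F)ccc1-c1ccnc2[nH]c(C3CCOCC3)cc12`, 3.9

Of the compounds shown here, two have been measured in a physicochemical assay for lipophilicity, using the shake flask method, measured as octanol-water partition, at pH 7.4; a lower number here means a more polar compound, a higher number a more lipophilic compound. Compound 1 gives -0.2, the lower of the two numbers. Compound 2, built on the same core but with different groups around it, gives 3.9 in this assay; the gap between compound 2 and compound 1 is far wider than the usual scatter of this measurement, so compound 1 is clearly the more polar of the pair. Since compound 2 differs from compound 1 in more than one place, the two values say nothing about any single structural change.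

Compound 3, `CC(C)n1cc(-c2ccnc3[nH]c(C4CCN(CC(=O)N(C)C)CC4)cc23)ccc1=O`, has not yet been measured. It differs from compound 1 in one place: (dimethylcarbamoyl)methyl in place of hydrogen on an amine nitrogen in a ring. Within the data shown here, no measured pair shows the effect of this exact change, so the step can only be estimated. A modest rise in this assay is expected, with the step from compound 1 to compound 3 estimated at a number 0.90 log units higher from compound 1 to compound 3 (beyond the scatter). Compound 3 is therefore expected to give about 0.7, in a range from -0.1 to 1.5.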

Compound 3, distribution coefficient: 1.9
The estimate for compound 3 lay 1.20 log units below the measured number, and the stated range ends below it.
By their numbers in this assay, from the lowest: compound 1; then compound 3; then compound 2.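

In this assay, putting (dimethylcarbamoyl)methyl in place of hydrogen on the amine nitrogen of the six-membered non-aromatic ring gives a large step, a number 2.10 log units higher from compound 1 to compound 3 (beyond the scatter), well beyond the usual scatter of repeated measurements. Among these compounds, this is the first reading of a single change in this set: the two compounds are otherwise identical, so the whole step belongs to this one exchange, and the ring nitrogen proves to be a place where a substituent can move this number strongly. Nothing measured here explains why the step has this size.

The compounds shown leave open whether the step comes from losing the hydrogen on that nitrogen or from the atoms of the added group, since both happen together in this one exchange. From the compounds shown here alone, a plain methyl, a longer chain ending in a dimethylamide, or a chain ending in a carboxylic acid on the same nitrogen could separate these two readings, and whether the step would be the same on a different core also remains open.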